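This account rests on a few compounds, and the source may have more. Where it says the series, first, only, none or still open, it means among the compounds named here.

Compound 1, `O=C(O)Cc1sc(C(c2ccccc2)c2ccc(Cl)cc2)nc1-c1ccc(Cl)cc1`, gives 75 nM in an in vitro functional assay on HEK285-7 cells for antagonist activity at prostaglandin D2 receptor 2 (Homo sapiens), read by BRET and beta-arrestin recruitment; a higher number here means a weaker inhibitor, a lower number a stronger inhibitor.
Compound 2, `O=C(O)Cc1sc(C(c2ccc(F)cc2)c2ccc(F)cc2)nc1-c1ccncc1`, gives 40 nM in this assay.

Among the measured compounds shown here, of the two numbers measured so far in this assay, compound 2 has the lower one, but the nearest other value, that of compound 1, lies within the usual scatter of repeated measurements, so the two compounds cannot be separated on these data. Compound 3, `CN(C)c1cc(-c2nc(C(c3ccc(F)cc3)c3ccc(F)cc3)sc2CC(=O)O)ccn1`, has not yet been measured. It differs from compound 2 in one place: dimethylamino in place of hydrogen on an aromatic carbon. For the measured compounds named here, no step between measured compounds is known here that would show what such a change does in this assay, and the two measured values say nothing about it. A step of no more than the usual scatter is therefore expected, in either direction, and the estimate stays close to compound 2. The expected step is a 1.1-fold lower number from compound 2 to compound 3 (0.06 log units; within the scatter). Compound 3 is expected to give 35 nM, within a range of 12 nM to 110 nM.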

Compound 3, half-maximal inhibitory concentration: > 100000 nM
Compound 3: a limit, no number (the forecaster's own chance of this, stated with the estimate: 3%); middle value at least 2800-fold (3.45 log units) away from the limit.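

The change from pyridin-4-yl to 2-(dimethylamino)pyridin-4-yl gives, in this assay, an at least 2500-fold higher number from compound 2 to compound 3 (3.39 log units; beyond the scatter). Until now no step had shown what any change does in this assay, and this one shows that a single dimethylamino group, on the aromatic carbon next to the ring nitrogen, is enough to remove measurable inhibition. The result for compound 3 is a limit of the assay and not a number: the limit of > 100000 nM in this assay, at which 1 of the 3 values shown sits.

The compounds shown leave open whether an amino, methyl or methoxy group on this same carbon would give a similarly large step or one within the scatter. They also leave open whether dimethylamino on another carbon of this ring would have the same outcome.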